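A bromo to fluoro exchange in a small series

The compounds below may be only part of what the source reports. "The series", "measured", "known", "first", "only" and "open" are said of these compounds alone.

Measured in a functional assay on the whole organism (strain Kunming) with Mus musculus as the target, with a stated time of 0.5 h (a higher number here means that more compound is needed for the effect, a lower number that less compound is needed), the compounds gave these values:
compound 1 `COc1cc(OC)c(OC)cc1/C=C/COC(=O)/C=C/c1c(OC)ccc(OC)c1OC` gives 476 umol/kg
compound 2 `COc1cc(OC)c(OC)cc1/C=C/COC(=O)/C=C/c1cc(OC)c(OC)c(OC)c1OC` gives 327 umol/kg
compound 3 `COc1cc(OC)c(OC)cc1/C=C/COC(=O)/C=C/c1ccc(Br)cc1` gives 446 umol/kg

Compound 3 at 446 umol/kg lies within the scatter of compound 1 at 476 umol/kg and of compound 2 at 327 umol/kg in this series. Compound 4 `COc1cc(OC)c(OC)cc1/C=C/COC(=O)/C=C/c1ccc(F)cc1` has fluoro in place of bromo on an aromatic carbon, para to a large group, a change counted as fluoro in place of bromo on an aromatic carbon in full. Among the measured compounds shown here, no measured pair differs in one place only, so the expectation rests on compound 3 at 446 umol/kg and on the narrow spread of the three values. In this assay no step beyond the scatter is expected, and the estimate is a 1.1-fold lower number from compound 3 to compound 4 (0.03 log units; within the scatter) in size. For compound 4 the estimated value is 420 umol/kg with an expected range from 240 umol/kg to 730 umol/kg as its span.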

Compound 4, dose for half-maximal effect: 449 umol/kg
Compound 4: the middle estimate sits 1.1-fold (0.03 log units) below what was measured; low and high end bracket the measured number.
By their numbers in this assay, from the lowest: compounds 2, 3, 4 and 1 (each within the scatter of the next).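

Among the compounds shown here, compounds 3 and 4 form the only pair here that differs in one place, so the change from 4-bromophenyl to 4-fluorophenyl can be read directly in this assay: the exchange gives a 1.0-fold higher number from compound 3 to compound 4 (0.00 log units; within the scatter). At this position, para to a large group, this read-out does not separate fluoro from bromo. Nothing available gives a reason for this result.

As far as these compounds go, whether an amine, a carboxylic acid or a longer chain at this position would leave the number as unmoved remains open. So does the outcome of a plain hydrogen there.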